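The source may hold more compounds than are shown below. What is called first, only, known or untested is meant among the compounds shown, and "the series" means these compounds.

Measured compounds in an assay on CHO cells for antagonist activity at transient receptor potential cation channel subfamily V member 1 (Homo sapiens), read by FLIPR; on this read-out lower numbers stand for stronger inhibition and higher numbers for weaker inhibition:
Compound 1 `CCCN(CCC)c1cc(C(F)(F)F)ccc1CNC(=O)C(C)c1ccc(NS(C)(=O)=O)c(F)c1` gives 0.3 nM.
Compound 2 `CC(C(=O)NCc1ccc(C(F)(F)F)cc1N1CCCC1)c1ccc(NS(C)(=O)=O)c(F)c1` gives 2.3 nM.
Compound 3 `CCC1CCN(c2cc(C(F)(F)F)ccc2CNC(=O)C(C)c2ccc(NS(C)(=O)=O)c(F)c2)CC1` gives 0.7 nM.

Among these three, compound 3 stands in the middle: compound 1 sits lower, a step of a 2.3-fold higher number from compound 1 to compound 3 (0.37 log units; beyond the scatter) separating them, while compound 2 sits higher, with a step of a 3.3-fold lower number from compound 2 to compound 3 (0.52 log units; beyond the scatter) down to compound 3. Both steps are beyond the scatter, but neither is large.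

Compound 4 `CC(C(=O)NCc1ccc(C(F)(F)F)cc1N1CCC(C)(C)CC1)c1ccc(NS(C)(=O)=O)c(F)c1` is the next compound. It differs from compound 3 in one place: 4,4-dimethylpiperidin-1-yl in place of 4-ethylpiperidin-1-yl on an aromatic carbon. The two groups that swap have the same atom count and the same ring, so the change is a rearrangement of the same pieces rather than an addition or removal.

Within the data shown here, the steps that bear on this change are those that vary the same group on the same aromatic carbon: a 2.3-fold higher number from compound 1 to compound 3 (0.37 log units; beyond the scatter) and a 3.3-fold lower number from compound 2 to compound 3 (0.52 log units; beyond the scatter). Both were modest, and they show that a six-membered ring at this position gave a number between those of the open dipropylamino chain and the smaller pyrrolidine ring. Because compound 3 with its six-membered ring gives 0.7 nM, and because the new group keeps that ring, the expected step in this assay is small, probably within the scatter, with no clear direction.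

The estimate for compound 4 is therefore 0.8 nM, with a range from 0.3 nM to 2.5 nM, a step of a 1.1-fold higher number from compound 3 to compound 4 (0.06 log units; within the scatter).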

Compound 4, inhibition constant: 1.3 nM
Compound 4: middle estimate off by 1.6-fold (0.21 log units), on the low side, within the range that was stated.
By their numbers in this assay, from the lowest: compound 1; then compounds 3, 4 and 2 (each within the scatter of the next, the first and the last beyond it).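

In this assay, rearranging the same carbons on the same six-membered ring gives a 1.9-fold higher number from compound 3 to compound 4 (0.27 log units; within the scatter), so at this aromatic carbon 4-ethylpiperidin-1-yl and 4,4-dimethylpiperidin-1-yl cannot be told apart. The new compound also softens a gap that looked real among the ring amines: a 1.8-fold lower number from compound 2 to compound 4 (0.25 log units; within the scatter) places it within the scatter of the pyrrolidin-1-yl compound as well, even though that compound and the 4-ethylpiperidin-1-yl compound lie beyond the scatter of each other, so the three ring amines now read as one loose group with overlapping values. Only the open dipropylamino group stays clearly apart from the new compound, with a 4.3-fold higher number from compound 1 to compound 4 (0.64 log units; beyond the scatter), and nothing measured here says why.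

The compounds shown leave open whether a ring carrying a second hetero atom, such as morpholine or piperazine, would fall in with these ring amines at this aromatic carbon. They also leave open whether a shorter open chain, such as diethylamino, would match dipropylamino or join the rings.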